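The compounds below may be only part of what the source reports. "The series", "measured", "known", "first", "only" and "open" are said of these compounds alone.

Measured compounds:
Compound 1, `COc1cc2c(Oc3ccc(NC(=O)NN4C(=O)CSC4c4c(F)cccc4F)cc3Cl)ccnc2cc1OCCCN1CCCC1`, gives 880 nM in a functional assay on A549 cells (Homo sapiens) for antiproliferative activity, read by MTT assay, with a stated time of 72 h; a higher number here means a weaker inhibitor, a lower number a stronger inhibitor.
Compound 2, `COc1cc2c(Oc3ccc(NC(=O)NN4C(=O)CSC4c4c(F)cccc4F)c4ccccc34)ccnc2cc1OCCCN1CCCC1`, gives 2360 nM in this assay.
Compound 3, `CCN1CCN(CCCOc2cc3nccc(Oc4c(F)cc(NC(=O)NN5C(=O)CSC5c5c(F)cccc5F)cc4F)c3cc2OC)CC1`, gives 350 nM in this assay.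

Compound 3 holds the lowest number of the three, so it is the strongest inhibitor here; compound 1 sits higher and compound 2 highest, both gaps being beyond the scatter. Compound 4, `COc1cc2c(Oc3c(F)cc(NC(=O)NN4C(=O)CSC4c4c(F)cccc4F)cc3F)ccnc2cc1OCCCN1CCC(C)CC1`, is not yet measured. It differs from compound 3 only at the end of the chain: 4-methylpiperidin-1-yl in place of 4-ethylpiperazin-1-yl on a saturated chain carbon, three bonds along the chain from an oxygen on an aromatic ring. For the measured compounds named here, no measured pair shows this change, so its effect is unknown. The change is small and far from the urea, and the step from compound 3 to compound 4 is expected to be a 1.2-fold higher number from compound 3 to compound 4 (0.08 log units; within the scatter), within the scatter. Compound 4 is therefore estimated at 420 nM, with a range from 150 nM to 1200 nM.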

Compound 4, half-maximal inhibitory concentration: 970 nM
Compound 4: the middle estimate sits 2.3-fold (0.36 log units) below what was measured; measured number inside the range.
By their numbers in this assay, from the lowest: compound 3; then compounds 1 and 4 (each within the scatter of the next); then compound 2.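

Exchanging 4-ethylpiperazin-1-yl for 4-methylpiperidin-1-yl at the end of the chain gives a 2.8-fold higher number from compound 3 to compound 4 (0.44 log units; beyond the scatter) in this assay, a modest step. For the compounds shown here, this position therefore affects the antiproliferative reading, and this pair is the first direct sign of it. No measurement at hand bears on why the step occurs.

Two things change together here: the ring's second nitrogen gives way to carbon, and ethyl gives way to methyl. A 4-methylpiperazin-1-yl group in the same place could help tell these two changes apart.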